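Pyridine Replaces Methoxyphenyl on a Shared Amide Core

The compounds below may be only part of what the source reports. "The series", "measured", "known", "first", "only" and "open" are said of these compounds alone.

Of the compounds shown here, two on a shared core have been tested in a toxicity assay on THP-1 cells (Homo sapiens) for inhibition; a lower number here means that less compound is tolerated, a higher number that more compound is tolerated. Compound 1 `COc1ccc(-c2cnc(NC(=O)c3ccno3)n2C)cc1` carries a 1,2-oxazol-5-yl group on the carbonyl carbon; in this assay compound 1 reaches only the limit of the assay, > 100000 nM. Compound 2 `COc1ccc(-c2cnc(NC(=O)c3cccc(OC)c3)n2C)cc1` carries a 3-methoxyphenyl group in that position. In this assay compound 2 likewise gives only the limit, > 100000 nM. The step between them, a step that the two limits leave unreadable from compound 1 to compound 2, therefore cannot be read in size or direction; both values sit at the same limit (the limit of > 100000 nM in this assay, at which 2 of the 2 values shown sit).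

Compound 3 `COc1ccc(-c2cnc(NC(=O)c3ccccn3)n2C)cc1` is the next compound. Its change from compound 2 is pyridin-2-yl in place of 3-methoxyphenyl on a carbonyl carbon. Within the data shown here, no measured step speaks directly to this change, since the only step available is unreadable. With both neighbours at the limit, no shift beyond the usual scatter is expected, and the step of a number no higher from compound 2 to compound 3 (the limit leaves the size open) is estimated to be flat. Compound 3 is therefore expected to give about 100000 nM, within 50000 nM to 200000 nM, most likely again only as a limit.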

Compound 3, half-maximal cytotoxic concentration: > 100000 nM
Compound 3: no number, only a limit; the forecaster's own chance of this, stated with the estimate: 80%; the middle value sits exactly at the limit.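

Compound 3 also gives only a limit in this assay, so the steps linking compound 1, compound 2 and compound 3 cannot be read in size or direction: the limit of > 100000 nM in this assay, at which 3 of the 3 values shown sit.

The compounds shown leave open whether 1,2-oxazol-5-yl, 3-methoxyphenyl and pyridin-2-yl on the carbonyl carbon differ at all in how much compound is tolerated.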